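The source may hold more compounds than are shown below. What is called first, only, known or untested is meant among the compounds shown, and "the series" means these compounds.

Measured so far in a functional assay (muscle tissue) with Cavia porcellus as the target; a higher number here means that more compound is needed for the effect, a lower number that less compound is needed:
compound 1 `COC(=O)C1=C(C)N=C(C)/C(=C(\O)OC)C1c1ccccc1C(F)(F)F` gives 1.51 nM;
compound 2 `CCOc1ccccc1C1C(C(=O)OC)=C(C)N=C(C)/C1=C(\O)OC` gives 110 nM;
compound 3 `COC(=O)C1=C(C)N=C(C)/C(=C(\O)OC)C1c1ccccc1Br` gives 7.59 nM.

Compound 3 stands second highest of the three: compound 1 is nearest, with a 5.0-fold higher number from compound 1 to compound 3 (0.70 log units; beyond the scatter), and compound 2 furthest, with a 14-fold lower number from compound 2 to compound 3 (1.16 log units; beyond the scatter). Compound 4 `COC(=O)C1=C(C)N=C(C)/C(=C(\O)OC)C1c1cccc(I)c1` differs from compound 3 by 3-iodophenyl in place of 2-bromophenyl on a saturated ring carbon. For the measured compounds named here, no measured step bears directly on this change: the steps seen so far swap groups on one aromatic carbon, while here the halogen changes and the whole phenyl group is exchanged. The halogen-bearing compounds 1 and 3 both give low numbers, so a modest rise, not a large one, is expected: a 2.0-fold higher number from compound 3 to compound 4 (0.30 log units; within the scatter). Compound 4 is therefore expected to give about 15 nM, between 2.5 nM and 90 nM.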

Compound 4, half-maximal effective concentration: 41.7 nM
For compound 4 the middle estimate is 2.8-fold (0.44 log units) below the measured one, and the stated range covers the measured number.
By their numbers in this assay, from the lowest: compound 1; then compound 3; then compound 4; then compound 2.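

In this assay, 3-iodophenyl in place of 2-bromophenyl on the saturated ring carbon brings a 5.5-fold higher number from compound 3 to compound 4 (0.74 log units; beyond the scatter), so two phenyl groups that each carry one halogen are not interchangeable at this position. Unlike the earlier steps, this one changes the halogen and its place on the phenyl group together, and the share of each cannot be separated. Nothing measured accounts for the rise.

Still open, going by these compounds, is where 3-bromophenyl or 2-iodophenyl would fall, which would separate the two changes. Also open, on these data alone, is how an amine or a carboxylic acid on the phenyl group would compare.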